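Replacing a Fused Ring System with a Methylated Aminopyridine

The source may hold more compounds than are shown below. What is called first, only, known or untested is meant among the compounds shown, and "the series" means these compounds.

Compound 2 `Fc1cc(-n2nnc(-c3ccccn3)n2)cc(-n2ccc3ccncc32)c1` has the lowest number of the three measured compounds: in a functional assay for antagonist activity at metabotropic glutamate receptor 5 (Homo sapiens) (on this read-out lower numbers stand for stronger inhibition and higher numbers for weaker inhibition), compound 2 gives 16 nM. Compound 3 `N#Cc1cccc(-n2nnc(-c3ccccn3)n2)c1` gives 73 nM in this assay, and compound 1 `c1ccc(-c2nnn(-c3ccccc3Oc3cccnc3)n2)nc1` gives 1580 nM; both gaps lie beyond the scatter, so compound 2 is the strongest of the three. Compound 4 `CN(c1cccnc1)c1cc(F)cc(-n2nnc(-c3ccccn3)n2)c1` is not yet measured. It differs from compound 2 in one place: a group of 8 heavy atoms (6 carbon, 2 nitrogen; one six-membered aromatic ring with 1 hetero atom) in place of a group of 9 heavy atoms (7 carbon, 2 nitrogen; one five-membered aromatic ring with 1 hetero atom, one six-membered aromatic ring with 1 hetero atom), on an aromatic carbon. Going by the values given here, no step of this kind has been measured. Among the compounds with values here, a weaker result seems likely, since compound 1, the only measured compound carrying a pyridine through a flexible link, gives 1580 nM, though compound 1 differs from compound 2 elsewhere too. Compound 4 is therefore expected to give 80 nM, with a range from 25 nM to 300 nM. The expected step is a 5.0-fold higher number from compound 2 to compound 4 (0.70 log units; beyond the scatter), toward weaker inhibition.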

Compound 4, half-maximal inhibitory concentration: 22 nM
Estimate against measurement, compound 4: 3.6-fold (0.56 log units) above, outside the stated range (below it).
By their numbers in this assay, from the lowest: compounds 2 and 4 (each within the scatter of the next); then compound 3; then compound 1.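

In this assay, putting methyl(pyridin-3-yl)amino in place of the fused group gives a 1.4-fold higher number from compound 2 to compound 4 (0.14 log units; within the scatter). This position on the carbon-only ring therefore does not depend on a fused pair of rings: a single pyridine ring joined through a methylated nitrogen reads the same on this assay. Nothing measured here explains why the two groups read alike. Still open, from the compounds shown here alone, is how a secondary amine link without the methyl would read at this position, and whether a plain phenyl group could replace the pyridine.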